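Fluoro to trifluoromethyl on the shared core, second pair

The source may report more compounds than this note shows. Statements on the series, on what has been measured and on what is new or still open speak of the compounds shown alone.

Measured so far:
compound 1 `CC(=O)Oc1ccc(/C=C/C(=O)OCCSc2nc(-c3ccc(S(C)(=O)=O)cc3)n(-c3ccc(F)cc3)n2)cc1OC(C)=O` — 12800 nM
compound 2 `CC(=O)Oc1ccc(/C=C/C(=O)OCCSc2nc(-c3ccc(S(C)(=O)=O)cc3)n(-c3ccc(C(F)(F)F)cc3)n2)cc1OC(C)=O` — 11300 nM
compound 3 `COc1cc(/C=C/C(=O)OCCSc2nc(-c3ccc(S(C)(=O)=O)cc3)n(-c3ccc(F)cc3)n2)ccc1OC(C)=O` — 10800 nM

In a functional assay on Caco-2 cells (Homo sapiens) for antiproliferative activity, read by MTT assay, with a stated time of 72 h (a lower number here means a stronger inhibitor, a higher number a weaker inhibitor), compound 3 gives 10800 nM, and its gaps to compound 1 and compound 2 are both within the scatter, so no ordering among the three can be drawn. Compound 4 `COc1cc(/C=C/C(=O)OCCSc2nc(-c3ccc(S(C)(=O)=O)cc3)n(-c3ccc(C(F)(F)F)cc3)n2)ccc1OC(C)=O` differs from compound 3 by trifluoromethyl in place of fluoro on an aromatic carbon. The same exchange has been run once on the shared core, a 1.1-fold lower number from compound 1 to compound 2 (0.05 log units; within the scatter), and the change on the other side of the core, a 1.2-fold lower number from compound 1 to compound 3 (0.07 log units; within the scatter), was also flat. The expectation for compound 4 is therefore a step of a 1.1-fold lower number from compound 3 to compound 4 (0.04 log units; within the scatter), none beyond the scatter, because of a 1.1-fold lower number from compound 1 to compound 2 (0.05 log units; within the scatter). Compound 4 is estimated at 9800 nM, with a range from 5000 nM to 20000 nM.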

Compound 4, half-maximal inhibitory concentration: 10800 nM
Beside the measured number, compound 4's estimate is 1.1-fold (0.04 log units) below it, and the stated range covers the measured number.
By their numbers in this assay, from the lowest: compounds 3, 4, 2 and 1 (each within the scatter of the next).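

In this assay, 4-fluorophenyl to 4-(trifluoromethyl)phenyl now stands on a second core, with no change at the digits printed from compound 3 to compound 4 (within the scatter), so this position shows a flat result on both cores: the same change on two cores in this assay, a 1.1-fold lower number (0.05 log units; within the scatter) from compound 1 to compound 2 and no change at the digits printed (within the scatter) from compound 3 to compound 4, 1.1-fold (0.05 log units) apart, within the scatter of two such steps. Methyl in place of acetyl on an oxygen on an aromatic ring also repeats, with a 1.0-fold lower number from compound 2 to compound 4 (0.02 log units; within the scatter), and the two cores agree: the same change on two cores in this assay, a 1.2-fold lower number (0.07 log units; within the scatter) from compound 1 to compound 3 and a 1.0-fold lower number (0.02 log units; within the scatter) from compound 2 to compound 4, 1.1-fold (0.05 log units) apart, within the scatter of two such steps.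

On these data alone, whether an amine or a carboxylic acid at this position would move the number beyond the scatter stays open. So does the effect of a longer chain at the ester.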